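Adding a Nitro Group to a Compound at the Limit

The compounds below may be only part of what the source reports. "The series", "measured", "known", "first", "only" and "open" are said of these compounds alone.

In a functional assay on K562 cells (Homo sapiens) for cytotoxicity, read by MTT assay, with a stated time of 5 days (on this read-out higher numbers stand for weaker inhibition and lower numbers for stronger inhibition), compound 1 (`COc1ccc(-c2cnnn2-c2cc(OC)c(OC)c(OC)c2)cc1N`) gives a measured number (11 nM). Compound 2 (`COc1ccc(-c2cnnn2Cc2cc(OC)c(OC)c(OC)c2)cc1Br`) reports only a limit (> 10000 nM). Compound 3 (`COc1ccc(Cn2cc(-c3cc(OC)c(OC)c(OC)c3)nn2)cc1`) also reports only a limit (> 10000 nM). Compound 3 therefore stands at the limit of > 10000 nM in this assay, at which 2 of the 3 values shown sit, and offers no exact number to start from.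

Compound 4 (`COc1ccc(Cn2cc(-c3cc(OC)c(OC)c(OC)c3)nn2)cc1[N+](=O)[O-]`) differs from compound 3 in a single place (nitro in place of hydrogen on an aromatic carbon). It has a nitro in place of hydrogen on an aromatic carbon, ortho to a methoxy group.

Among the measured compounds shown here, no measured pair of compounds differing in one place is available as a guide. The expectation in this assay is therefore no step beyond the usual scatter, with compound 4 probably reporting a limit as well. The expected step that the limit leaves unreadable from compound 3 to compound 4 is what this estimate amounts to. The estimate for compound 4 is 12000 nM within an expected range of 3000 nM to 40000 nM (an estimate, not a measurement).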

Compound 4, half-maximal inhibitory concentration: > 10000 nM
Compound 4 ended at the assay's limit; the forecaster's own chance of this, stated with the estimate: 80%; the middle value does not contradict the limit.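

Compound 3 and compound 4 both report only a limit and not a number, so no step can be read between them: the limit of > 10000 nM in this assay, at which 3 of the 4 values shown sit.

As far as these compounds go, how far each compound lies past that limit, and whether the nitro in place of hydrogen changes anything there, stays open.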